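Hydroxyethoxymethyl to benzyl on the shared core

The source may hold more compounds than are shown below. What is called first, only, known or untested is meant among the compounds shown, and "the series" means these compounds.

Working notes on the series, followed in a functional assay on HT-29 cells (Homo sapiens) for cytotoxicity; a higher number here means a weaker inhibitor, a lower number a stronger inhibitor. Compound 1 `Nc1[nH]nc2nnc(-c3ccccn3)c(-c3ccccn3)c12` gives 73000 nM. Compound 2 `Nc1ccc(-c2[nH]nc3nnc(N)c-3c2-c2ccc(N)cc2)cc1` gives 10500 nM. Compound 3 `Nc1nn(COCCO)c2nnc(-c3ccccc3)c(-c3ccccc3)c12` gives only a limit of the assay, > 100000 nM, and so stands at the limit of > 100000 nM in this assay, at which 1 of the 3 values shown sits. Among the three, compound 3 is thus the only one without a number. Among the measured compounds shown here, no pair of measured compounds differs in one place, so no measured step guides the next change. Compound 4 `Nc1nn(Cc2ccccc2)c2nnc(-c3ccccc3)c(-c3ccccc3)c12` differs from compound 3 by phenyl in place of 2-hydroxyethoxy on a saturated chain carbon bound to an aromatic nitrogen. With compound 3 known only as a limit, the step of an at least 1.4-fold lower number from compound 3 to compound 4 (0.15 log units; that floor lies within the scatter) is expected to be small, with no sure direction beyond the scatter. Compound 4 is estimated at 70000 nM, between 15000 nM and 250000 nM.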

Compound 4, half-maximal inhibitory concentration: > 100000 nM
Compound 4 was reported as a limit; the forecaster's own chance of this, stated with the estimate: 45%; middle value at least 1.4-fold (0.15 log units) from the limit.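

No step can be read from compound 3 to compound 4, as both stand only at a limit of the assay: the limit of > 100000 nM in this assay, at which 2 of the 4 values shown sit.

The compounds shown leave open whether the change from (2-hydroxyethoxy)methyl to benzyl alters the read-out at all.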